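A few compounds are considered here, and "the series" means these few. Any claim that something is new, unique, unknown or untested is made for them only; others in the source may bear on it.

Working notes on the series, read in a functional assay on MCF7 cells (Homo sapiens) for inhibition; a lower number here means a stronger inhibitor, a higher number a weaker inhibitor. Compound 1 `O=C(CC(CC(=O)NC1Cc2ccccc2C1)c1ccc(Cl)cc1)NCCN1CCCC1` returns only a limit of the assay, > 100000 nM. Among the compounds with values here, compound 3 `CN(C(=O)CC(CC(=O)NCCN1CCCC1)c1ccc(Cl)cc1)C1Cc2ccccc2C1` gives 76700 nM, and compound 2 `CCN(C(=O)CC(CC(=O)NCCN1CCCC1)c1ccc(Cl)cc1)C1Cc2ccccc2C1` gives 20400 nM, the lowest number so far.

The next change leads to compound 4 `CCNCCNC(=O)CC(CC(=O)N(CC)C1Cc2ccccc2C1)c1ccc(Cl)cc1`: ethylamino in place of pyrrolidin-1-yl on a saturated chain carbon, two bonds along the chain from an amide-type nitrogen. In words, ethylamino replaces pyrrolidin-1-yl on a saturated chain carbon, two bonds along the chain from an amide-type nitrogen.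

Within the data shown here, no measured step touches this group. All three change the substituent on the other amide-type nitrogen: an at least 4.9-fold lower number from compound 1 to compound 2 (0.69 log units; beyond the scatter), an at least 1.3-fold lower number from compound 1 to compound 3 (0.11 log units; that floor lies within the scatter) and a 3.8-fold higher number from compound 2 to compound 3 (0.58 log units; beyond the scatter). Among the measured compounds shown here, they therefore give no direction for the new change and show only that a single change can shift the number modestly, as in a 3.8-fold higher number from compound 2 to compound 3 (0.58 log units; beyond the scatter). No step beyond the scatter is therefore expected, though one of similar modest size in either direction cannot be excluded.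

The expected change is a 1.2-fold higher number from compound 2 to compound 4 (0.09 log units; within the scatter). For compound 4 the estimated value is 25000 nM, with an expected range of 8000 nM to 80000 nM.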

Compound 4, half-maximal inhibitory concentration: 14400 nM
Beside the measured number, compound 4's estimate is 1.7-fold (0.24 log units) above it; the range from low to high includes it.
By their numbers in this assay, from the lowest: compounds 4 and 2 (each within the scatter of the next); then compound 3. At a limit, above all of these: compound 1.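

In this assay, within the data shown here, the only step read at this position gives a 1.4-fold lower number from compound 2 to compound 4 (0.15 log units; within the scatter), so compound 2 and compound 4 cannot be told apart. For this pair, the ring of pyrrolidin-1-yl is not required to keep the number at this level, and the open ethylamino, with its hydrogen-bond donor, is accepted on a saturated chain carbon, two bonds along the chain from an amide-type nitrogen, while the ethyl on the other amide-type nitrogen stays in place. No information at hand gives a cause for this outcome.

As far as these compounds go, it remains open how a hydroxyl or a carboxylic acid in place of the ethylamino would read, and whether a longer chain ahead of the amine would shift the number. Also open, from the compounds shown here alone, is whether ethylamino reads the same with methyl or hydrogen on the other amide-type nitrogen.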